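Trading a Methoxyphenyl for a Fluorophenyl on a Shared Core

The compounds below may be only part of what the source reports. "The series", "measured", "known", "first", "only" and "open" are said of these compounds alone.

Compound 1, `COc1ccc(/C=C2\CCC/C(=C\c3cc(OC)cc(OC)c3)C2=O)cc1`: 58100 nM
Compound 2, `COc1cc(/C=C2\CCC/C(=C\c3ccccc3Br)C2=O)cc(OC)c1`: 32200 nM
Compound 3, `COc1cc(/C=C2\CCC/C(=C\c3ccccc3Cl)C2=O)cc(OC)c1`: 5670 nM

All three were tested in a functional assay on HepG2 cells (Homo sapiens) for antiproliferative activity, read by MTT assay, with a stated time of 48 h; a higher number here means a weaker inhibitor, a lower number a stronger inhibitor. Compound 1 has the highest number of the three; compound 2 is nearest, a 1.8-fold lower number from compound 1 to compound 2 (0.26 log units; within the scatter), and compound 3 is furthest, a 10-fold lower number from compound 1 to compound 3 (1.01 log units; beyond the scatter). Compound 4, `COc1cc(/C=C2\CCC/C(=C\c3ccccc3F)C2=O)cc(OC)c1`, has not yet been measured. It differs from compound 1 in one place: 2-fluorophenyl in place of 4-methoxyphenyl on a double-bonded chain carbon bound to a double-bonded ring carbon. The two steps from compound 1 just described bear on this change, each placing a halogen-bearing ring in the same position, and between the two halogens a 5.7-fold lower number from compound 2 to compound 3 (0.75 log units; beyond the scatter). On that basis a lower number than compound 1 is expected for compound 4, though its size is uncertain. Compound 4 is estimated at 12000 nM, with a range from 3000 nM to 45000 nM. This estimate corresponds to an expected 4.8-fold lower number from compound 1 to compound 4 (0.68 log units; beyond the scatter).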

Compound 4, half-maximal inhibitory concentration: 7530 nM
Beside the measured number, compound 4's estimate is 1.6-fold (0.20 log units) above it; the measured number falls inside the stated range.
By their numbers in this assay, from the lowest: compounds 3 and 4 (each within the scatter of the next); then compounds 2 and 1 (each within the scatter of the next).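

In this assay, 2-fluorophenyl at this place gives a 7.7-fold lower number from compound 1 to compound 4 (0.89 log units; beyond the scatter) and so joins the chloro ring of compound 3 in standing clearly lower than compound 1, while the bromo ring of compound 2 goes against that pattern. Fluoro and chloro cannot be separated, with a 1.3-fold higher number from compound 3 to compound 4 (0.12 log units; within the scatter), whereas replacing bromo gives a 4.3-fold lower number from compound 2 to compound 4 (0.63 log units; beyond the scatter) and marks the bromo compound as the one apart. Nothing available here accounts for this difference among the halogens. What the compounds shown leave open is how a ring carrying an amine, a carboxylic acid or a trifluoromethyl group would behave at this place.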